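A few compounds are considered here, and "the series" means these few. Any claim that something is new, unique, unknown or untested is made for them only; others in the source may bear on it.

Compound 1 `O=C(Nc1cccc(-c2ccc(-c3ccccc3)cc2)c1)C(Cl)Cl`: 10900 nM
Compound 2 `O=C(Nc1cc(-c2ccc(OC3CCCCO3)cc2)cc(-c2ccc(OC3CCCCO3)cc2)c1)C(Cl)Cl`: 2420 nM
Compound 3 `COc1ccccc1-c1cc(NC(=O)C(Cl)Cl)cc(-c2ccccc2OC)c1`: > 30000 nM (a limit of the assay, not a number)

In a functional assay on NCI-H460 cells (Homo sapiens) for cytotoxicity, read by MTT assay, with a stated time of 68 h (a higher number here means a weaker inhibitor, a lower number a stronger inhibitor), compound 1 gives 10900 nM, the higher of the two true numbers available. Compound 2 gives the lower number, 2420 nM, and the gap between them lies beyond the usual scatter. Compound 3 reaches only a limit of the assay, > 30000 nM.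

Compound 4 `O=C(Nc1cccc(-c2ccc(Cl)cc2)c1)C(Cl)Cl` has not yet been measured. It keeps the core of compound 1 but carries chloro in place of phenyl on an aromatic carbon, para to a large group: chloro in place of phenyl on an aromatic carbon.

With more rings than compound 1, compound 2 reads 2420 nM, so losing a ring might be expected to raise the number a little. Compound 3 goes against this pattern: it also carries an extra ring, yet its result is the limit > 30000 nM. The evidence is therefore thin, and in this assay only a small step toward a weaker inhibitor is expected, possibly none beyond the scatter. The expected change is a 1.2-fold higher number from compound 1 to compound 4 (0.08 log units; within the scatter). For compound 4 the estimate is 13000 nM, with an expected range of 5000 nM to 30000 nM.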

Compound 4, half-maximal inhibitory concentration: > 50000 nM
Compound 4: a limit, no number; the forecaster's own chance of this, stated with the estimate: 15%; middle value at least 3.8-fold (0.58 log units) away from the limit.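

In this assay, chloro in place of phenyl on an aromatic carbon, para to a large group, gives an at least 4.5-fold higher number from compound 1 to compound 4 (0.66 log units; beyond the scatter). Compounds 1 and 4 are the first pair shown that differ in only one place, so this step ties a clear loss of cytotoxic effect to this single change, which comparisons among compounds 1, 2 and 3 could not do. The result for compound 4 is a limit of the assay and not a number, so the true step could be larger than the one printed: the limit of > 50000 nM in this assay, at which 1 of the 4 values shown sits.

No measured property is given for either group, so the data show that the change matters but not why. The compounds shown leave open whether the outer ring itself is needed or whether another group, such as an amine or a butyl chain, could take the place of phenyl in this assay. They also leave open whether the same change would cost as much on the core of compound 2.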